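Swapping Nitro for Hydroxy on the Phenyl Ring

The source may report more compounds than this note shows. Statements on the series, on what has been measured and on what is new or still open speak of the compounds shown alone.

In a functional assay (muscle tissue) with Cavia porcellus as the target (a lower number here means that less compound is needed, a higher number that more compound is needed for the effect), compound 3 `COC(=O)C1=C(C)N=C(C)/C(=C(\O)OC)C1c1cccc([N+](=O)[O-])c1` gives the lowest of the three numbers, at 3.98 nM. Compound 1 `C=Cc1ccccc1C1C(C(=O)OC)=C(C)N=C(C)/C1=C(\O)OC` gives 4.47 nM in this assay, a value within the scatter of compound 3. Compound 2 `COC(=O)C1=C(C)N=C(C)/C(=C(\O)OC)C1c1cccc(C)c1` gives 110 nM, and the step of a 28-fold lower number from compound 2 to compound 3 (1.44 log units; beyond the scatter) follows nitro in place of methyl on an aromatic carbon. Compound 4 `COC(=O)C1=C(C)N=C(C)/C(=C(\O)OC)C1c1cccc(O)c1` differs from compound 3 by hydroxy in place of nitro on an aromatic carbon. Within the data shown here, only the step from compound 2 to compound 3 touches this position, and it was large, so a change there can matter; no measured compound carries a hydroxy, so the direction is uncertain. The author expects a moderately higher number for compound 4, a step of a 7.5-fold higher number from compound 3 to compound 4 (0.88 log units; beyond the scatter), with compound 4 estimated at 30 nM, between 4 nM and 250 nM.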

Compound 4, half-maximal effective concentration: 1000 nM
Estimate against measurement, compound 4: 33-fold (1.52 log units) below, outside the stated range (above it).
By their numbers in this assay, from the lowest: compounds 3 and 1 (each within the scatter of the next); then compound 2; then compound 4.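

Compound 4 has the highest number of the four in this assay, so methyl does not mark the upper end at this aromatic carbon: hydroxy for nitro gives a 250-fold higher number from compound 3 to compound 4 (2.40 log units; beyond the scatter), and hydroxy for methyl gives a 9.1-fold higher number from compound 2 to compound 4 (0.96 log units; beyond the scatter). The comparison with the 2-vinylphenyl compound agrees, with a 220-fold higher number from compound 1 to compound 4 (2.35 log units; beyond the scatter). No measured evidence bears on why hydroxy gives this result. As far as these compounds go, whether an amine, a methoxy or a carboxylic acid here would stand closer to nitro or to hydroxy stays open.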